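The source may report more compounds than this note shows. Statements on the series, on what has been measured and on what is new or still open speak of the compounds shown alone.

Measured compounds in a functional assay on the whole organism (strain NMRI) with Mus musculus as the target, in the maximal electroshock model, with a stated time of 4 h; on this read-out lower numbers stand for an effect already at smaller amounts and higher numbers for an effect only at larger amounts of compound:
- compound 1 `Cc1ccc(-c2nc3ccc(Br)cn3c2/C=N/OCc2cn(Cc3ccc([N+](=O)[O-])cc3)nn2)cc1`: 100 mg/kg
- compound 2 `O=[N+]([O-])c1ccc(Cn2cc(CO/N=C/c3c(-c4ccc(F)cc4)nc4ccc(Br)cn34)nn2)cc1`: 100 mg/kg
- compound 3 `O=[N+]([O-])c1ccc(Cn2cc(CO/N=C/c3c(-c4ccccc4)nc4ccc(Br)cn34)nn2)cc1`: 40 mg/kg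

Compound 2 stands level with compound 1, and together these two share the highest number of the three. Compound 3 sits apart from both: a 2.5-fold lower number from compound 1 to compound 3 (0.40 log units; beyond the scatter) and a 2.5-fold lower number from compound 2 to compound 3 (0.40 log units; beyond the scatter), while no change at the digits printed from compound 1 to compound 2 (within the scatter).

Compound 4 `N#Cc1ccc(Cn2cc(CO/N=C/c3c(-c4ccc(F)cc4)nc4ccc(Br)cn34)nn2)cc1` is not yet measured. It differs from compound 2 in one place: cyano in place of nitro on an aromatic carbon. All three measured steps concern the other phenyl ring, where methyl, fluoro and hydrogen are exchanged; none of them touches the nitro group or the benzyl part. So no measured step bears directly on the change from compound 2 to compound 4, and the exchange of nitro for cyano at this position is untested here.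

Without a relevant precedent, compound 4 is expected to stay close to compound 2, at 100 mg/kg with a range from 40 mg/kg to 250 mg/kg, which means an estimated no change at the digits printed from compound 2 to compound 4 (within the scatter), within the scatter.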

Compound 4, minimum effective dose: 100 mg/kg
Beside the measured number, compound 4's estimate shows no gap at the digits printed; measured number inside the range.
By their numbers in this assay, from the lowest: compound 3; then compounds 1, 2 and 4 (each within the scatter of the next).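

In this assay, going by these compounds alone, the earlier steps all concerned the other phenyl ring, and this is the first step at the far end of the benzyl part: cyano in place of nitro gives no change at the digits printed from compound 2 to compound 4 (within the scatter). The nitro group is therefore not needed to keep this number, at least in a compound that carries fluoro on the other phenyl ring, and 4-cyanobenzyl serves here as well as 4-nitrobenzyl. Nothing shown here explains why the two groups read alike.

On these data alone, it remains open whether the same exchange would also leave the number unmoved with hydrogen on the other phenyl ring, as in compound 3 at 40 mg/kg. Also open, as far as these compounds go, is how an amine, a carboxylic acid or plain hydrogen would read at this place on the benzyl part.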